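The source may report more compounds than this note shows. Statements on the series, on what has been measured and on what is new or still open speak of the compounds shown alone.

Measured compounds:
- Compound 1 `COc1cc2c(Nc3nc4ccc(C(=O)Nc5c(C)cccc5Cl)cc4s3)ncnc2cc1OCCCN1CCCC1`: 63800 nM
- Compound 2 `COc1cc2c(Nc3nc4ccc(C(=O)Nc5c(C)cccc5Cl)cc4s3)ncnc2cc1OCCCN1CCCCC1`: 23400 nM

In a functional assay on HCT-116 cells (Homo sapiens) for cytotoxicity, read by WST assay, with a stated time of 72 h (a higher number here means a weaker inhibitor, a lower number a stronger inhibitor), compound 1 gives 63800 nM and compound 2 gives 23400 nM. Among the compounds with values here, the two differ only at the amine on the chain: the step of a 2.7-fold lower number from compound 1 to compound 2 (0.44 log units; beyond the scatter) lowers the number, so compound 2 stands as the lowest of the two numbers in this assay, and compound 1 is its only neighbour.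

Compound 3 `COc1cc2c(Nc3nc4ccc(C(=O)Nc5c(C)cccc5Cl)cc4s3)ncnc2cc1OCCCN1CCC(C)CC1` is not yet measured. It differs from compound 2 by methyl in place of hydrogen on a saturated ring carbon. Within the data shown here, the single step seen so far, a 2.7-fold lower number from compound 1 to compound 2 (0.44 log units; beyond the scatter), concerns a change in ring size at the same amine, not a substituent on that ring, so it bears on the present change only loosely: it shows that this part of the molecule can move the number in this assay, but not in which direction a methyl on the ring would do so.

With so little to rest on, compound 3 is expected to give roughly 18000 nM in this assay, within a range of 7000 nM to 50000 nM. The estimated step of a 1.3-fold lower number from compound 2 to compound 3 (0.11 log units; within the scatter) is expected to stay within the scatter of repeated measurements.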

Compound 3, half-maximal inhibitory concentration: 9100 nM
Estimate against measurement, compound 3: 2.0-fold (0.30 log units) above, within the range that was stated.
By their numbers in this assay, from the lowest: compound 3; then compound 2; then compound 1.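

In this assay, a methyl on the saturated ring carbon three ring bonds from the ring nitrogen gives a 2.6-fold lower number from compound 2 to compound 3 (0.41 log units; beyond the scatter), so a substituent on this ring can shift the number beyond the scatter, and here it lowers it. Within the data shown here, until now, only a change of ring size at this amine had been seen; the full change from pyrrolidin-1-yl to 4-methylpiperidin-1-yl gives a 7.0-fold lower number from compound 1 to compound 3 (0.85 log units; beyond the scatter), and within these three compounds both the larger ring and the added methyl go the same way, with no compound going against that. Nothing available here explains why the methyl has this effect.

The compounds shown leave open whether the number would keep falling with an ethyl or a tert-butyl on that same ring carbon, or whether a hydroxyl there would do the same as the methyl. They also leave open what would happen if the ring were a morpholine or a 4-methylpiperazine, or if a longer chain linked the ring to the oxygen on the aromatic ring.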